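This account rests on a few compounds, and the source may have more. Where it says the series, first, only, none or still open, it means among the compounds named here.

The three measured compounds, each with its result in a functional assay on MCF7 cells (Homo sapiens) for cytotoxicity, read by MTT assay, with a stated time of 48 h; a higher number here means a weaker inhibitor, a lower number a stronger inhibitor:

Compound 1, `Fc1ccc(Nc2nc(-c3cccc(F)c3)nc3ccc(F)cc23)cc1`: > 50000 nM, a limit of the assay.
Compound 2, `Fc1cccc(-c2nc(Nc3cccc(Br)c3)c3cc(F)ccc3n2)c1`: > 50000 nM, a limit of the assay.
Compound 3, `Fc1cccc(-c2nc(Nc3ccccc3Br)c3cc(F)ccc3n2)c1`: > 50000 nM, a limit of the assay.

Compound 1 therefore stands at the assay limit rather than at a number, and every value shown is such a limit, as the limit of > 50000 nM in this assay, at which 3 of the 3 values shown sit, records. The steps a step that the two limits leave unreadable from compound 1 to compound 2, a step that the two limits leave unreadable from compound 1 to compound 3 and a step that the two limits leave unreadable from compound 2 to compound 3 accordingly give no readable size. Compound 4, `Cc1ccc(Nc2nc(-c3cccc(F)c3)nc3ccc(F)cc23)cc1`, differs from compound 1 by methyl in place of fluoro on an aromatic carbon. Within the data shown here, none of the measured steps touches this change: each exchanges the 4-fluorophenyl on the nitrogen for a 3-bromophenyl or a 2-bromophenyl, and none yields a number. Since every compound of this core sits at the limit, as the limit of > 50000 nM in this assay, at which 3 of the 3 values shown sit, shows, compound 4 is expected to remain there as well. The step that the limit leaves unreadable from compound 1 to compound 4 is estimated to be none beyond the scatter. Compound 4 is estimated at 80000 nM, with a range from 30000 nM to 200000 nM.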

Compound 4, half-maximal inhibitory concentration: > 50000 nM
Compound 4 ended at the assay's limit; the forecaster's own chance of this, stated with the estimate: 85%; the middle value does not contradict the limit.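

No new step can be read in this assay, as compound 4 joins compound 1, compound 2 and compound 3 at the assay limit, leaving its steps to each unreadable: the limit of > 50000 nM in this assay, at which 4 of the 4 values shown sit. The compounds shown leave open which change to the shared core, if any, would give a measurable value.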